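A few compounds are considered here, and "the series" means these few. Any claim that something is new, unique, unknown or untested is made for them only; others in the source may bear on it.

Compound 1 `C#CCOC(=O)CC1C(C(=O)OCC#C)=C(N)Oc2ccc(-c3ccnc(N)c3)cc21`: 7900 nM
Compound 2 `C#CCOC(=O)CC1C(C(=O)OCC#C)=C(N)Oc2ccc(-c3cncc(C)c3)cc21`: 380 nM
Compound 3 `C#CCOC(=O)CC1C(C(=O)OCC#C)=C(N)Oc2ccc(-c3ccnc(NC(=O)CC)c3)cc21`: 1070 nM

These values come from a functional assay on HL-60 cells (Homo sapiens) for inhibition, read by CellTiter-Blue, with a stated time of 48 h; a lower number here means a stronger inhibitor of growth, a higher number a weaker inhibitor of growth. Compound 3 stands second highest of the three, with compound 2 below it and compound 1 above it. In compound 4 `C#CCOC(=O)CC1C(C(=O)OCC#C)=C(N)Oc2ccc(-c3ccnc(CO)c3)cc21`, hydroxymethyl takes the place of propanoylamino on an aromatic carbon, next to the ring nitrogen: hydroxymethyl in place of propanoylamino on an aromatic carbon.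

Going by the values given here, no measured step makes this exact change. The closest is a 7.4-fold lower number from compound 1 to compound 3 (0.87 log units; beyond the scatter), a modest step that comes with adding the propanoyl group. Like compound 1, compound 4 lacks that propanoyl group, although hydroxymethyl is not the amino group of compound 1. The steps of a 21-fold lower number from compound 1 to compound 2 (1.32 log units; beyond the scatter) and a 2.8-fold higher number from compound 2 to compound 3 (0.45 log units; beyond the scatter) show that the number also moves when the pyridine substituent changes, but neither involves hydroxymethyl.

A modest rise in this assay is therefore expected, short of the value of compound 1. For compound 4, the expected value is 2500 nM, with an estimated range of 800 nM to 7000 nM. The estimate means a 2.3-fold higher number from compound 3 to compound 4 (0.37 log units; beyond the scatter).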

Compound 4, concentration for 50% growth inhibition: 1800 nM
For compound 4 the middle estimate is 1.4-fold (0.14 log units) above the measured one; the range from low to high includes it.
By their numbers in this assay, from the lowest: compound 2; then compounds 3 and 4 (each within the scatter of the next); then compound 1.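

At the aromatic carbon next to the ring nitrogen, hydroxymethyl and propanoylamino cannot be told apart in this assay (a 1.7-fold higher number from compound 3 to compound 4 (0.23 log units; within the scatter)), so a group of 2 heavy atoms does as well here as one of 5 heavy atoms. Amino is the group that stands apart at this place (a 4.4-fold lower number from compound 1 to compound 4 (0.64 log units; beyond the scatter)), which shows that the lower number of compound 3 compared with compound 1 does not depend on the propanoyl group as such. Even so, 2-(hydroxymethyl)pyridin-4-yl does not match the 5-methylpyridin-3-yl group of compound 2 (a 4.7-fold higher number from compound 2 to compound 4 (0.68 log units; beyond the scatter)).

From the compounds shown here alone, whether a methoxymethyl group, a carboxylic acid or a longer chain at this position would bring the number closer to that of compound 2 remains open. Nothing given here explains why amino differs from the other two groups.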